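The compounds below may be only part of what the source reports. "The series", "measured", "known", "first", "only" and "open" are said of these compounds alone.

In an ADME assay on a cell-free system (plasma, Rattus norvegicus) for metabolic stability, read by LC-MS, with a stated time of 60 min, tested at 100 uM (on this read-out higher numbers stand for a more stable compound and lower numbers for a less stable compound), three compounds have been measured:

compound 1, `COc1cc(C(=O)O)ccc1OCCCCOc1ccc(C(=O)CC(C)C)c(O)c1C`, gives 99%;
compound 2, `Cc1c(OCCCCOc2ccc(C(=O)O)cc2)ccc(C(=O)CC(C)C)c1O`, gives 95%;
compound 3, `Cc1c(OCCCCOc2cccc(C(=O)O)c2)ccc(C(=O)CC(C)C)c1O`, gives 100%.

All three values lie close together, and the two steps between them stay inside the scatter. From compound 2 to compound 1 the change is methoxy in place of hydrogen on an aromatic carbon, and it brings a number 4 percentage points higher from compound 2 to compound 1 (within the scatter). From compound 2 to compound 3 the cores differ by 3-carboxyphenyl in place of 4-carboxyphenyl on an oxygen on a saturated carbon, with a number 5 percentage points higher from compound 2 to compound 3 (within the scatter).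

Compound 4, `COc1ccc(C(=O)O)cc1OCCCCOc1ccc(C(=O)CC(C)C)c(O)c1C`, has not yet been measured. It differs from compound 3 by methoxy in place of hydrogen on an aromatic carbon. Within the data shown here, this is the same kind of change as the one from compound 2 to compound 1, but not the same: there the methoxy sits meta to the carboxy group, here it sits para to it. Since the earlier step was within the scatter, the step from compound 3 to compound 4 is expected to be small as well, about a number 2 percentage points lower from compound 3 to compound 4 (within the scatter). Compound 4 is therefore estimated at 98%, between 92% and 100%.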

Compound 4, percent of the compound remaining: 99%
Compound 4: middle estimate off by 1 percentage points, on the low side, and the stated range covers the measured number.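

In this assay, methoxy in place of hydrogen on an aromatic carbon gives a number 1 percentage points lower from compound 3 to compound 4 (within the scatter). Set beside the earlier step, the change reads alike on the two cores: the same change on two cores in this assay, a number 4 percentage points higher (within the scatter) from compound 2 to compound 1 and a number 1 percentage points lower (within the scatter) from compound 3 to compound 4, 5 percentage points apart, within the scatter of two such steps. This shows that in these two cases the methoxy leaves the read-out within the scatter, but it does not show that a step of a given size carries from one core to another, as both steps are small and the methoxy on compound 4 stands para to a carboxy group, a place it does not share with the methoxy on compound 1.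

The compounds shown leave open whether a chlorine or an amine on the same aromatic carbon would stay as close to these values, and whether they would hold with a longer chain joining the two aromatic rings or with an amide in place of the carboxy group. They also say nothing about any read-out other than this assay.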